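Phenyl in place of pyrrolidin-1-yl in the series

The source may report more compounds than this note shows. Statements on the series, on what has been measured and on what is new or still open speak of the compounds shown alone.

compound 1 `O=C(/C=C/c1ccc([N+](=O)[O-])o1)c1ccc(I)cc1` gives 2100 nM
compound 2 `CSc1ccc(C(=O)/C=C/c2ccc([N+](=O)[O-])o2)cc1` gives 1600 nM
compound 3 `O=C(/C=C/c1ccc([N+](=O)[O-])o1)c1ccc(N2CCCC2)cc1` gives 16400 nM

In a functional assay on C6 cells (Rattus norvegicus) for inhibition, read by sulforhodamine B assay, with a stated time of 72 h (a higher number here means that more compound is needed for the effect, a lower number that less compound is needed), compound 3 stands highest of the three, and its steps to both others lie beyond the scatter. The change to compound 4 `O=C(/C=C/c1ccc([N+](=O)[O-])o1)c1ccc(-c2ccccc2)cc1` is phenyl in place of pyrrolidin-1-yl on an aromatic carbon and reads as phenyl in place of pyrrolidin-1-yl on an aromatic carbon. Among the compounds with values here, two measured steps bear on it: a 7.8-fold higher number from compound 1 to compound 3 (0.89 log units; beyond the scatter) is modest and a 10-fold higher number from compound 2 to compound 3 (1.01 log units; beyond the scatter) is large, both bringing in pyrrolidin-1-yl at that place. The step of a 1.3-fold lower number from compound 1 to compound 2 (0.12 log units; within the scatter) shows no separation between the two groups replaced. Read backward, these suggest a modest to large step toward a lower number in this assay for compound 4 if phenyl tracks iodo and methylsulfanyl, which no measurement yet shows. The expected step is a 5.5-fold lower number from compound 3 to compound 4 (0.74 log units; beyond the scatter) on this reading. Compound 4 is estimated at 3000 nM with an expected range from 1000 nM to 9000 nM in this assay.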

Compound 4, half-maximal effective concentration: 17700 nM
Compound 4: the middle estimate sits 5.9-fold (0.77 log units) below what was measured, outside the stated range (above it).
By their numbers in this assay, from the lowest: compounds 2 and 1 (each within the scatter of the next); then compounds 3 and 4 (each within the scatter of the next).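

In this assay the swap gives a 1.1-fold higher number from compound 3 to compound 4 (0.03 log units; within the scatter) and does not separate phenyl from pyrrolidin-1-yl at this position. The same compound stands apart from the iodo and methylsulfanyl compounds, with an 11-fold higher number from compound 2 to compound 4 (1.04 log units; beyond the scatter) and an 8.4-fold higher number from compound 1 to compound 4 (0.93 log units; beyond the scatter) showing that the high numbers here are not particular to pyrrolidin-1-yl and occur with both a non-aromatic and an aromatic ring. Nothing measured here explains this split. From the compounds shown here alone, whether dimethylamino or cyclopropyl would fall with iodo and methylsulfanyl or with phenyl and pyrrolidin-1-yl remains open.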